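A Reversed Amide and a Basic Side Chain

The source may report more compounds than this note shows. Statements on the series, on what has been measured and on what is new or still open speak of the compounds shown alone.

Compound 1 `O=C(CCSc1ccc2c(/C=C/c3ccccn3)n[nH]c2c1)Nc1cccc(C(F)(F)F)c1` and compound 3 `O=C(NCCSc1ccc2c(/C=C/c3ccccn3)n[nH]c2c1)c1cccc(C(F)(F)F)c1` are built from the same atoms joined differently; the difference between the two cores is not broken down here. In an ADME assay on BaF3 cells (Mus musculus) for antiproliferative activity, read by CCK-8 assay, with a stated time of 72 h (on this read-out higher numbers stand for weaker inhibition of growth and lower numbers for stronger inhibition of growth), compound 1 gives 2300 nM, and in this assay compound 3 gives 1500 nM. The two numbers lie within the scatter of each other, so no order between them can be claimed.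

Compound 2 `CN1CCN(Cc2ccc(NC(=O)CCSc3ccc4c(/C=C/c5ccccn5)n[nH]c4c3)cc2C(F)(F)F)CC1` differs from compound 1 by (4-methylpiperazin-1-yl)methyl in place of hydrogen on an aromatic carbon. In this assay compound 2 gives 2480 nM, and the step of a 1.1-fold higher number from compound 1 to compound 2 (0.03 log units; within the scatter) is flat within the scatter.

Compound 4 `CN1CCN(Cc2ccc(C(=O)NCCSc3ccc4c(/C=C/c5ccccn5)n[nH]c4c3)cc2C(F)(F)F)CC1` has not yet been measured in this assay. It differs from compound 3 by (4-methylpiperazin-1-yl)methyl in place of hydrogen on an aromatic carbon. This is the same change as the one from compound 1 to compound 2, entering at a place described in the same words, and it is the only such change among these compounds that has been measured. Because that single instance gave a 1.1-fold higher number from compound 1 to compound 2 (0.03 log units; within the scatter), compound 4 is expected to show a step of a 1.1-fold higher number from compound 3 to compound 4 (0.03 log units; within the scatter), essentially flat. This expectation rests on compound 3, which gives 1500 nM, and on the step of a 1.1-fold higher number from compound 1 to compound 2 (0.03 log units; within the scatter). Compound 4 is accordingly estimated at 1600 nM, with a range from 700 nM to 3600 nM allowing for the scatter and for the different core.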

Compound 4, concentration for 50% growth inhibition: 4800 nM
Compound 4: middle estimate off by 3.0-fold (0.48 log units), on the low side; the measured number lies above the stated range.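

On the second core, in this assay, the (4-methylpiperazin-1-yl)methyl group in place of hydrogen gives a 3.2-fold higher number from compound 3 to compound 4 (0.51 log units; beyond the scatter), a modest loss of growth inhibition where the same change on the first core was flat. The change therefore did not carry over with the same size from one core to the other, and the two steps differ by more than repeated measurements would explain: the same change on two cores in this assay, a 1.1-fold higher number (0.03 log units; within the scatter) from compound 1 to compound 2 and a 3.2-fold higher number (0.51 log units; beyond the scatter) from compound 3 to compound 4, 3.0-fold (0.47 log units) apart, beyond the scatter of two such steps This shows that, for these two cores, the size of the step depends on the core it is made on, but with only two instances it does not show why the steps differ or what size the step would take on any further core.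

The compounds shown leave open whether the gap belongs to the (4-methylpiperazin-1-yl)methyl group as a whole or would also appear with another amine, such as a morpholine or a dimethylamine, carried on the same methyl on both cores. They also leave open whether a longer chain in the amide-bearing linker would bring the two steps closer together or push them further apart.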